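From methyl to ethyl on the shared core

This account rests on a few compounds, and the source may have more. Where it says the series, first, only, none or still open, it means among the compounds named here.

In a functional assay on HeLa cells (Homo sapiens) for antiproliferative activity, read by sulforhodamine B assay (on this read-out lower numbers stand for stronger inhibition of growth and higher numbers for weaker inhibition of growth), compound 1 (`CCC[C@@H]1O[C@H](COCc2ccccc2)[C@@H](OCc2ccccc2)[C@H](OCc2ccccc2)[C@@H]1O`) gives a measured 23300 nM. Compound 2 (`C[C@@H]1O[C@H](COCc2ccccc2)[C@@H](OCc2ccccc2)[C@H](OCc2ccccc2)C1=O`) gives > 50000 nM, which is a limit of the assay and not a number. On these data alone, compound 2 therefore stands on (the limit of > 50000 nM in this assay, at which 1 of the 2 values shown sits), so its true position is unknown.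

Compound 3 (`CC[C@@H]1O[C@H](COCc2ccccc2)[C@@H](OCc2ccccc2)[C@H](OCc2ccccc2)C1=O`) departs from compound 2 by a single change: methyl in place of hydrogen on a saturated chain carbon bound to a saturated ring carbon. This is methyl in place of hydrogen on a saturated chain carbon bound to a saturated ring carbon, so that methyl becomes ethyl. Going by the values given here, no measured step for this change is available, and compound 1 differs from compound 2 in more than this one place.

In this assay, no step beyond the usual scatter is expected, and any shift is expected to be small and toward slightly stronger inhibition of growth. This expectation rests on compound 2, whose > 50000 nM is a limit. The estimated change is an at least 1.1-fold lower number from compound 2 to compound 3 (0.04 log units; that floor lies within the scatter). Compound 3 may well return only a limit too. For compound 3 the expected value is 45000 nM, with an estimated range from 20000 nM to 60000 nM.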

Compound 3, concentration for 50% growth inhibition: > 50000 nM
Compound 3 was reported as a limit (the forecaster's own chance of this, stated with the estimate: 55%); middle value at least 1.1-fold (0.04 log units) from the limit.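

In this assay compound 2 and compound 3 both stand at a limit and not at a number, so no step can be read between them: the limit of > 50000 nM in this assay, at which 2 of the 3 values shown sit.

The compounds shown leave open how far either compound lies from that limit, and whether methyl to ethyl on the shared core changes growth inhibition at all.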